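The compounds below may be only part of what the source reports. "The series", "measured", "known", "first", "only" and "open" are said of these compounds alone.

Compound 1, `COC(=O)[C@H](C)[C@H]1CC[C@@](C)(CCC2=C(C)CCCC2(C)C)OO1`: in a functional assay on SK-MEL-28 cells (Homo sapiens) for inhibition (a higher number here means a weaker inhibitor of growth, a lower number a stronger inhibitor of growth), compound 1 reaches only the assay limit of > 25000 nM.
Compound 2, `C=C1CCC[C@H]2[C@](C)(CC[C@]3(C)CC[C@H]([C@@H](C)C(=O)O)OO3)[C@@H](C)CC[C@]12C`: in this assay compound 2 gives 3310 nM.

Within the data shown here, compound 2 thus carries the only real number in this assay; the other result, (the limit of > 25000 nM in this assay, at which 1 of the 2 values shown sits), is a limit rather than a measurement, so no comparison of size between the two can be drawn beyond saying that compound 1 stayed out of range.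

Compound 3, `C=C1CCC[C@H]2[C@](C)(CC[C@]3(C)CC[C@@H]([C@@H](C)C(=O)O)OO3)[C@@H](C)CC[C@]12C`, keeps everything of compound 2 except for one point: the two compounds have the same atoms and bonds and differ only in configuration as drawn: 1 of 7 stereo elements differ; a stereocentre at a saturated ring carbon is drawn R in compound 2 and S in compound 3. Among the measured compounds shown here, no pair of measured compounds here differs in only one place, so there is no measured step to lean on. A single inversion of this kind can shift growth inhibition either way; the expectation is for a step from compound 2 to compound 3 of a 1.5-fold higher number from compound 2 to compound 3 (0.18 log units; within the scatter), at most modest and not clearly beyond the usual scatter. Compound 3 is therefore estimated at 5000 nM, with a range of 1500 nM to 18000 nM.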

Compound 3, concentration for 50% growth inhibition: 2370 nM
For compound 3 the middle estimate is 2.1-fold (0.32 log units) above the measured one; the measured number falls inside the stated range.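

Inverting this one ring carbon, drawn R in compound 2 and S in compound 3, gives in this assay a 1.4-fold lower number from compound 2 to compound 3 (0.15 log units; within the scatter). Among these compounds, this is the first measured pair that differs in a single place, and it shows that at this stereocentre either configuration gives the same growth inhibition within the scatter, so neither compound can be ranked above the other. The reading is a direct one, since no other part of the structure changes: the fact that compounds 2 and 3 differ only in the configuration as drawn

Going by these compounds, whether the other six stereo elements can be inverted with as little consequence remains open, since only this one has been changed in a measured pair. Also open, on these data alone, is what would happen on this core if an amide or a primary alcohol stood in place of the carboxylic acid.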